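A few compounds are considered here, and "the series" means these few. Any claim that something is new, unique, unknown or untested is made for them only; others in the source may bear on it.

In a functional assay on MOLT-4 cells (Homo sapiens) for antiproliferative activity, with a stated time of 48 h (a higher number here means a weaker inhibitor, a lower number a stronger inhibitor), compound 1 (`C=C(Br)C(=O)Nc1ccc(/C=C/C(=O)c2ccc(F)cc2)cc1`) gives 660 nM, compound 3 (`C=C(Br)C(=O)Nc1ccc(/C=C/C(=O)c2cccc(OC)c2)cc1`) gives 850 nM and compound 2 (`C=C(Br)C(=O)Nc1ccc(/C=C/C(=O)c2ccc(Cl)c(Cl)c2)cc1`) gives 1800 nM, the highest number of the three. Compound 4 (`Nc1ccc(/C=C/C(=O)c2ccc(Cl)c(Cl)c2)cc1`) differs from compound 2 by hydrogen in place of (1-bromoethenyl)carbonyl on a nitrogen on an aromatic ring. The measured steps, a 2.7-fold higher number from compound 1 to compound 2 (0.44 log units; beyond the scatter), a 2.1-fold lower number from compound 2 to compound 3 (0.33 log units; beyond the scatter) and a 1.3-fold higher number from compound 1 to compound 3 (0.11 log units; within the scatter), all change the group on the carbonyl carbon, so none tests this change directly and they offer only a scale. All three measured compounds carry the group that is lost, so a rise larger than those steps is expected in this assay, though without direct support. The estimated step is a 5.6-fold higher number from compound 2 to compound 4 (0.74 log units; beyond the scatter). For compound 4 the expected value is 10000 nM, with an estimated range of 3000 nM to 30000 nM.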

Compound 4, half-maximal inhibitory concentration: 13000 nM
The estimate for compound 4 lay 1.3-fold (0.11 log units) below the measured number; the measured number falls inside the stated range.
By their numbers in this assay, from the lowest: compounds 1 and 3 (each within the scatter of the next); then compound 2; then compound 4.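

In this assay, for the compounds shown here, the change to hydrogen on the nitrogen on an aromatic ring gives a 7.2-fold higher number from compound 2 to compound 4 (0.86 log units; beyond the scatter) and is the first direct reading at this position. It is larger than a 2.7-fold higher number from compound 1 to compound 2 (0.44 log units; beyond the scatter) at the carbonyl carbon, so within these compounds the (1-bromoethenyl)carbonyl counts for more than the group changes there. Nothing at hand explains the rise.

As far as these compounds go, whether the bromine matters stays open, as an acetyl or a plain propenoyl on that nitrogen would separate it from the rest of the group. From the compounds shown here alone, the size of this change with 4-fluorophenyl or 3-methoxyphenyl on the carbonyl also stays open.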